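Removing a chloro from the central ring of compound 3

A few compounds are considered here, and "the series" means these few. Any claim that something is new, unique, unknown or untested is made for them only; others in the source may bear on it.

Three measured pyrazole acids share a common core. Compound 1 `Cc1cc(C(=O)O)nn1Cc1cc(Br)ccc1OCc1cccc(C(F)(F)F)c1` gives 309 nM in an assay on CHO-K1 cells for displacement of a labelled ligand from prostaglandin E2 receptor EP1 subtype (Homo sapiens); a higher number here means a weaker inhibitor, a lower number a stronger inhibitor. Compound 2 `Cc1cc(C(=O)O)nn1Cc1cc(Br)ccc1OCc1ccc(Cl)c(C(F)(F)F)c1` gives 575 nM in this assay. Compound 3 `Cc1cc(C(=O)O)nn1Cc1cc(Cl)ccc1OCc1ccc(Cl)cc1Cl` is reported in this assay only as a limit, < 2000 nM, which is a limit of the assay and not a number (the limit of < 2000 nM in this assay, at which 1 of the 3 values shown sits). The difference between the cores of compound 2 and compound 3 is not broken down here.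

Between compound 2 and compound 1 the change is hydrogen in place of chloro on an aromatic carbon, and it gives a 1.9-fold lower number from compound 2 to compound 1 (0.27 log units; within the scatter). The unmeasured compound 4 `Cc1cc(C(=O)O)nn1Cc1ccccc1OCc1ccc(Cl)cc1Cl` arises from compound 3 by hydrogen in place of chloro on an aromatic carbon. It is the same kind of change, but the place differs: in compound 2 the departing chloro sits ortho to a trifluoromethyl group and para to a large group, while in compound 3 it sits meta to a large group and para to a large group.

Because the earlier step of a 1.9-fold lower number from compound 2 to compound 1 (0.27 log units; within the scatter) was small, and because compound 3 offers only a limit (the limit of < 2000 nM in this assay, at which 1 of the 3 values shown sits), compound 4 is expected to land near its parent, a step that the limit leaves unreadable from compound 3 to compound 4 in this assay. Compound 4 is therefore estimated at 800 nM, with a likely range of 250 nM to 3000 nM.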

Compound 4, half-maximal inhibitory concentration: < 2000 nM
Compound 4: only a limit was reported (the forecaster's own chance of this, stated with the estimate: 30%); the middle value does not contradict the limit.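

In this assay, among the compounds shown here, compound 3 and compound 4 are both reported only as limits, so no step between them can be read: the limit of < 2000 nM in this assay, at which 2 of the 4 values shown sit. The compounds shown leave open where compound 3 and compound 4 actually stand, and so whether hydrogen in place of chloro at this place changes the number at all.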